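The source may hold more compounds than are shown below. What is called first, only, known or untested is meant among the compounds shown, and "the series" means these compounds.

Working notes on the series, followed in an assay for inhibition of Tryptophan 2,3-dioxygenase (Homo sapiens), with stated times of 10 min and 60 min; on this read-out higher numbers stand for weaker inhibition and lower numbers for stronger inhibition. Compound 1 `O=C(O)c1cccc(CNc2cc(C(F)(F)F)cc3[nH]ncc23)c1` gives 1690 nM. Compound 2 `FC(F)(F)c1cc(NC[C@@H]2CCCCN2)c2cn[nH]c2c1` gives 8050 nM, and compound 3 `FC(F)(F)c1cc(NC[C@H]2CCCCN2)c2cn[nH]c2c1` gives 460 nM. For the measured compounds named here, the only single-point step among the measured compounds is an 18-fold lower number from compound 2 to compound 3 (1.24 log units; beyond the scatter), and it rests on (the fact that compounds 2 and 3 differ only in the configuration as drawn). Going by the values given here, on the numbers so far compound 3 stands lowest of the three, nearest to compound 1 and furthest from compound 2.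

Compound 4 `FC(F)(F)c1cc(NCc2cccc(Br)c2)c2cn[nH]c2c1` is next. Against compound 3 the change is 3-bromophenyl in place of piperidin-2-yl on a saturated chain carbon bound to a nitrogen on an aromatic ring. Among the compounds with values here, no measured step covers such a replacement: the step in hand concerns configuration only and does not bear on it. What the values show is that compound 1, also carrying an aromatic ring on that chain carbon, gives 1690 nM, while compound 3 gives 460 nM. A higher number in this assay is therefore expected for compound 4, of moderate size but with wide uncertainty. Expected step: a 3.3-fold higher number from compound 3 to compound 4 (0.51 log units; beyond the scatter). Compound 4 is estimated at 1500 nM, within a range from 400 nM to 6000 nM.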

Compound 4, half-maximal inhibitory concentration: 19100 nM
The estimate for compound 4 lay 13-fold (1.10 log units) below the measured number; the whole stated range lies below it.
By their numbers in this assay, from the lowest: compound 3; then compound 1; then compound 2; then compound 4.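

With 3-bromophenyl on a saturated chain carbon bound to a nitrogen on an aromatic ring, the number rises well past that of piperidin-2-yl, with a 42-fold higher number from compound 3 to compound 4 (1.62 log units; beyond the scatter) and, even against the weaker configuration, a 2.4-fold higher number from compound 2 to compound 4 (0.38 log units; beyond the scatter) on the same replacement. An aromatic ring at this place is therefore not one outcome: the group on that ring matters, as shown by an 11-fold higher number from compound 1 to compound 4 (1.05 log units; beyond the scatter) for bromo in place of carboxy on an aromatic carbon. The one available explanation concerns configuration alone and gives no reason for either change.

Open, going by these compounds, is how much of the rise in compound 4 belongs to the ring and how much to the bromo, which an unsubstituted phenyl or a phenyl carrying an amine would help to separate. Also open, on these data alone, is whether a pyrrolidine, or a longer chain ending in an amine, would hold the number of compound 3.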